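The compounds below may be only part of what the source reports. "The series", "measured", "known", "first", "only" and "open" are said of these compounds alone.

Working notes on the series. Compound 1 `CC(C)(C)c1ccc(C(=O)NCc2ccc(NS(=O)(=O)C(F)(F)F)cc2Cl)cc1`, compound 2 `CC(C)(C)c1ccc(C(=O)NCc2c(F)cc(NS(C)(=O)=O)cc2F)cc1` and compound 3 `CS(=O)(=O)Nc1ccc(CNC(=O)c2ccc(C(F)(F)F)cc2)c(Cl)c1` have each been run in an ADME assay on microsomes from liver (Rattus norvegicus, strain Sprague-Dawley) for metabolic stability, read by HPLC, using NADPH, with stated times of 5 min and 60 min, tested at 10 uM; a lower number here means slower removal, a higher number faster removal of the compound. In this assay compound 1 gives 17 mL.min-1.g-1. Compound 2 gives 9.3 mL.min-1.g-1 in this assay. Compound 3 gives 9.6 mL.min-1.g-1 in this assay. The three numbers lie close together: the gap from compound 3 to compound 2 is well within the scatter, and the gap from compound 3 to compound 1, the widest of the three, is also within the scatter, so no ordering among them can be read from this assay.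

Compound 4 `CC(F)(F)c1ccc(C(=O)NCc2ccc(NS(C)(=O)=O)cc2Cl)cc1` has not yet been run in this assay. It differs from compound 3 in one place: methyl in place of fluoro on a saturated chain carbon bound to an aromatic carbon and two fluorine atoms. For the measured compounds named here, nothing measured separates this change from the scatter, since no pair of measured compounds differs by it. The expectation is a small step, if any, in the direction of a higher number, of a size that may still fall inside the scatter: the step from compound 3 to compound 4 is estimated at a 1.5-fold higher number from compound 3 to compound 4 (0.16 log units; within the scatter). On that basis compound 4 is expected to give about 14 mL.min-1.g-1 in this assay, with a range from 7 mL.min-1.g-1 to 28 mL.min-1.g-1.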

Compound 4, intrinsic clearance in microsomes: 9.6 mL.min-1.g-1
Estimate against measurement, compound 4: 1.5-fold (0.16 log units) above, within the range that was stated.
By their numbers in this assay, from the lowest: compounds 2, 3, 4 and 1 (each within the scatter of the next).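

For the compounds shown here, the only pair that differs in one place shows, in this assay, no change at the digits printed from compound 3 to compound 4 (within the scatter) when trifluoromethyl gives way to 1,1-difluoroethyl. Going by these compounds alone, earlier comparisons could not isolate any single change, whereas this pair shows that, on this core and in this read-out, methyl in place of fluoro on a saturated chain carbon bound to an aromatic carbon and two fluorine atoms leaves intrinsic clearance in microsomes without a step beyond the scatter; this rests on a single pair and sets no pattern for the series. Nothing available explains why the two compounds match.

Still open, going by these compounds, is whether another group at this place, such as a methoxy group, a nitrile or a cyclopropyl ring, would also leave the number in this assay within the scatter of compound 3. Also open, on these data alone, is whether the change from trifluoromethyl to 1,1-difluoroethyl gives a step of similar size on the core of compound 1 or the core of compound 2.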